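Swapping one small five-membered ring for another

The source may report more compounds than this note shows. Statements on the series, on what has been measured and on what is new or still open speak of the compounds shown alone.

Compound 3 `Cn1nccc1-c1cc(C(F)(F)F)ccc1[C@@H]1CCOc2cc(S(=O)(=O)Nc3nccs3)ccc21` was measured in a physicochemical assay for lipophilicity (on this read-out lower numbers stand for lower lipophilicity and higher numbers for higher lipophilicity), giving 2.2. Within the data shown here, its nearest neighbour is compound 1 `O=S(=O)(Nc1nccs1)c1ccc2c(c1)OCC[C@H]2c1ccc(C(F)(F)F)cc1-n1ccnn1`, which in this assay gives 2.3; the only single-point step recorded here, a number 0.10 log units lower from compound 1 to compound 3 (within the scatter), lies within the scatter, so the two values cannot be told apart. Compound 3 thus sits at the lowest of the two numbers, but not by a meaningful margin. Compound 2 `O=S(=O)(Nc1nccs1)c1ccc2c(c1)OCC[C@H]2c1ccc(C(F)(F)F)cc1-c1ccc(F)nc1` has no number in this assay; its entry reads "not determined" (no result reported).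

Compound 4 `Cc1nc(-c2cc(C(F)(F)F)ccc2[C@@H]2CCOc3cc(S(=O)(=O)Nc4nccs4)ccc32)co1` differs from compound 3 in one place: 2-methyl-1,3-oxazol-4-yl in place of 1-methyl-1H-pyrazol-5-yl on an aromatic carbon. Among the measured compounds shown here, no measured step covers this particular swap, and the one step that exists, the one from compound 1 to compound 3, was itself within the scatter. With two small rings of the same size and the same count of hetero atoms exchanged, no step beyond the scatter is expected, and the estimated move no change at the digits printed from compound 3 to compound 4 (within the scatter) is accordingly slight. For compound 4 the expected value in this assay is 2.2, within a range from 1.8 to 2.6.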

Compound 4, distribution coefficient: 2.9
Compound 4: the middle estimate sits 0.70 log units below what was measured, outside the stated range (above it).
By their numbers in this assay, from the lowest: compounds 3 and 1 (each within the scatter of the next); then compound 4.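

At this place on the ring, ortho to a large group and meta to a trifluoromethyl group, the choice of five-membered ring can clearly shift the result in this assay once 2-methyl-1,3-oxazol-4-yl enters. Replacing 1-methyl-1H-pyrazol-5-yl gives a number 0.70 log units higher from compound 3 to compound 4 (beyond the scatter) and replacing 1H-1,2,3-triazol-1-yl gives a number 0.60 log units higher from compound 1 to compound 4 (beyond the scatter) with the rest of the molecule unchanged. The earlier swap stayed within the scatter, and the matching counts of heavy atoms, hetero atoms, donors and acceptors for the pyrazolyl and oxazolyl groups show that such counts alone do not fix the read-out here.

Nothing available gives a reason for these steps. Where a morpholine, a carboxylic acid or a plain phenyl ring at this place would fall also remains open.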